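The source may report more compounds than this note shows. Statements on the series, on what has been measured and on what is new or still open speak of the compounds shown alone.

In a functional assay on HCT-116 cells (Homo sapiens) for antiproliferative activity, read by MTT assay, with a stated time of 72 h (on this read-out higher numbers stand for weaker inhibition and lower numbers for stronger inhibition), compound 3 `O=C1O[C@H]([C@@H](O)Cn2cc(CNS(=O)(=O)c3ccc(Cl)cc3)nn2)C(OCc2ccccc2)=C1OCc1ccccc1` gives 8380 nM, the lowest of the three numbers measured; compound 1 `O=C1O[C@H]([C@@H](O)Cn2cc(-c3ccc(Br)cc3)nn2)C(OCc2ccccc2)=C1OCc1ccccc1` gives 9420 nM, a gap within the scatter, and compound 2 `O=C1O[C@H]([C@@H](O)Cn2cc(CNS(=O)(=O)c3ccc(F)cc3)nn2)C(OCc2ccccc2)=C1OCc1ccccc1` gives 22900 nM, a gap beyond it. Compound 4 `Cc1ccc(S(=O)(=O)NCc2cn(C[C@H](O)[C@H]3OC(=O)C(OCc4ccccc4)=C3OCc3ccccc3)nn2)cc1` differs from compound 3 by methyl in place of chloro on an aromatic carbon. Among the compounds with values here, only one measured step changes that same position: a 2.7-fold lower number from compound 2 to compound 3 (0.44 log units; beyond the scatter), a modest shift; the other steps, a 2.4-fold higher number from compound 1 to compound 2 (0.39 log units; beyond the scatter) and a 1.1-fold lower number from compound 1 to compound 3 (0.05 log units; within the scatter), swap the whole side group and bear less on it. Within the data shown here, since the only para exchange moved the number modestly, the step to compound 4 is expected to be small, a 1.1-fold higher number from compound 3 to compound 4 (0.05 log units; within the scatter), with no clear direction. Compound 4 is therefore estimated at 9500 nM, within 4000 nM to 22000 nM, in this assay.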

Compound 4, half-maximal inhibitory concentration: 13100 nM
Compound 4: the middle estimate sits 1.4-fold (0.14 log units) below what was measured; measured number inside the range.
By their numbers in this assay, from the lowest: compounds 3, 1, 4 and 2 (each within the scatter of the next, the first and the last beyond it).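

In this assay methyl gives a third group on the aromatic carbon para to a large group, and a 1.6-fold higher number from compound 3 to compound 4 (0.19 log units; within the scatter) and a 1.7-fold lower number from compound 2 to compound 4 (0.24 log units; within the scatter) both stay within the scatter, although chloro and fluoro differ beyond it. Methyl therefore cannot be told apart from either halogen here. Swapping the whole side group also stays within the scatter, with a 1.4-fold higher number from compound 1 to compound 4 (0.14 log units; within the scatter) as the step. Nothing at hand explains these shifts. The compounds shown leave open whether an amine, a carboxylic acid or a methoxy group at this position would move the number further.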